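The source may hold more compounds than are shown below. What is called first, only, known or untested is meant among the compounds shown, and "the series" means these compounds.

Compound 1, `COC(=O)c1ccc(-c2nn(Cc3ccccc3)c3ccccc23)cc1`, in a functional assay on cells (Platelet, Homo sapiens) for inhibition (a higher number here means a weaker inhibitor, a lower number a stronger inhibitor), gives > 10000 nM, a limit of the assay rather than a number.
Compound 2, `CC(C)NC(=O)c1ccc(-c2nn(Cc3ccccc3)c3ccccc23)cc1`, in this assay gives > 10000 nM, again a limit.
Compound 3, `OCc1ccc(-c2nn(Cc3ccccc3)c3ccccc23)cc1`, in this assay gives > 10000 nM, also a limit.

Compound 3 therefore stands only at a limit, and the two other values shown share that limit, so that none of the three compounds can be ranked against another. The steps among them reflect this: a step that the two limits leave unreadable from compound 1 to compound 3 and a step that the two limits leave unreadable from compound 2 to compound 3, as well as a step that the two limits leave unreadable from compound 1 to compound 2. For the measured compounds named here, the single piece of evidence on these steps is the limit of > 10000 nM in this assay, at which 3 of the 3 values shown sit.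

Compound 4, `CCOC(=O)/C=C/c1ccc(-c2nn(Cc3ccccc3)c3ccccc23)cc1`, differs from compound 3 in one place: 2-(ethoxycarbonyl)ethenyl in place of hydroxymethyl on an aromatic carbon. The measured steps that bear on this change are the two leading into compound 3, from compound 1 and from compound 2, and both are unreadable in size because both ends sit at the limit. No step shown gives a readable size in either direction, so the expectation for this assay can only be that compound 4 most probably remains near the limit as well, with no step beyond the scatter that the data would support. On that basis compound 4 is estimated at 15000 nM, within a range of 3000 nM to 60000 nM, which means an expected step that the limit leaves unreadable from compound 3 to compound 4.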

Compound 4, half-maximal inhibitory concentration: > 10000 nM
Compound 4 was reported as a limit (the forecaster's own chance of this, stated with the estimate: 70%); the middle value lies beyond the limit too.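

In this assay compound 4 gives > 10000 nM, a limit. Its steps from compound 1, compound 2 and compound 3 therefore cannot be read, and no new comparison arises: the limit of > 10000 nM in this assay, at which 4 of the 4 values shown sit. The compounds shown leave open whether any group at this aromatic carbon of the shared core would give a measurable value in this assay.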